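This account rests on a few compounds, and the source may have more. Where it says the series, first, only, none or still open, it means among the compounds named here.

Of the compounds shown here, three have so far been measured in an ADME assay on the whole organism (thoracic aorta) with Rattus norvegicus as the target, in the presence of a further agent that is not named here; a higher number here means a larger maximal response, a lower number a smaller maximal response. Compound 3 `S=C=Nc1ccc(Cc2ncc[nH]2)cc1` gives 100%, the highest of the three numbers. Nearest to it is compound 1 `S=C=Nc1ccc(CCC2=NCCN2)cc1` with 21%, and furthest is compound 2 `S=C=Nc1ccc(OCC2=NCCN2)cc1` with 11%; both gaps to compound 3 lie beyond the scatter. Compound 4 `S=C=Nc1ccc(CC2=NCCN2)cc1` has not yet been measured. It differs from compound 3 in one place: a group of 5 heavy atoms (3 carbon, 2 nitrogen; one five-membered non-aromatic ring with 2 hetero atoms) in place of a group of 5 heavy atoms (3 carbon, 2 nitrogen; one five-membered aromatic ring with 2 hetero atoms), on a saturated chain carbon bound to an aromatic carbon. Because compound 1 gives 21% and compound 2 gives 11%, both carrying a five-membered non-aromatic ring with 2 hetero atoms, a downward step beyond the scatter is expected in this assay. The expected step is a number 65 percentage points lower from compound 3 to compound 4 (beyond the scatter). For compound 4 the estimated value is 35%, in a range from 10% to 80%.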

Compound 4, largest response reached (Emax), in percent of the reference or control that the assay uses: 42%
Beside the measured number, compound 4's estimate is 7 percentage points below it; the range from low to high includes it.
By their numbers in this assay, from the lowest: compounds 2 and 1 (each within the scatter of the next); then compound 4; then compound 3.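

Replacing the 1H-imidazol-2-yl group with the five-membered non-aromatic ring on a saturated chain carbon bound to an aromatic carbon gives in this assay a number 58 percentage points lower from compound 3 to compound 4 (beyond the scatter) with the rest of the structure unchanged. Among these compounds, this isolates the ring exchange as a large downward step at this position, whereas the earlier compounds with the non-aromatic ring also differed from compound 3 in their linking chains. No measurement shown here explains the size of this step. Going by these compounds, it remains open whether a longer chain carrying the 1H-imidazol-2-yl group would retain the response of compound 3. An amine or a carboxylic acid in this place also remains untested among the compounds shown.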